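Exchanging the side chain of compound 2

A few compounds are considered here, and "the series" means these few. Any claim that something is new, unique, unknown or untested is made for them only; others in the source may bear on it.

In an ADME assay (liver) for metabolic stability, with Liver microsome (Rattus norvegicus) as the target, using microsomes and NADPH, with a stated time of 30 min (a lower number here means slower removal, a higher number faster removal of the compound), compound 1 `CC#C[C@H]1CN(S(=O)(=O)c2ccc(N)nc2)CCN1c1ccccc1` gives > 399 mL.min-1.g-1, which is a limit of the assay and not a number. For the measured compounds named here, compound 2 `CC#CCC(O)(c1ccc(N2CCN(S(=O)(=O)c3ccc(N)nc3)C[C@@H]2C#CC)cc1)C(F)(F)F` gives 115 mL.min-1.g-1, the only true number so far, so it has no neighbour with a true number to be ranked against. Going by the values given here, one measured step bears on what follows: an at least 3.4-fold lower number from compound 1 to compound 2 (0.54 log units; beyond the scatter). As far as these compounds go, it came with a group of 10 heavy atoms in place of a hydrogen atom, on an aromatic carbon, and its full size stays open.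

Compound 3 `CC#C[C@H]1CN(S(=O)(=O)c2ccc(N)nc2)CCN1c1ccc([C@](O)(CO)C(F)(F)F)cc1` changes that same group on that aromatic carbon, which is para to a large group: a group of 8 heavy atoms (3 carbon, 2 oxygen, 3 fluorine; no ring) in place of a group of 10 heavy atoms (6 carbon, 1 oxygen, 3 fluorine; no ring), on an aromatic carbon. A 1,2-dihydroxy-1-(trifluoromethyl)ethyl group enters, and the triple bond outside aromatic rings in the leaving group is gone. Among the compounds with values here, no measured step tests such an exchange, so the expectation is tentative. A further moderate fall is expected from compound 2 at 115 mL.min-1.g-1. The expected change is a 2.6-fold lower number from compound 2 to compound 3 (0.41 log units; beyond the scatter). For compound 3 the estimate is 45 mL.min-1.g-1, with an expected range of 15 mL.min-1.g-1 to 120 mL.min-1.g-1.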

Compound 3, intrinsic clearance in microsomes: < 14 mL.min-1.g-1
Compound 3 was reported as a limit; the forecaster's own chance of this, stated with the estimate: 10%; middle value at least 3.2-fold (0.50 log units) away from the limit.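

In this assay, the aromatic carbon para to a large group turns out to respond not only to adding a side chain but also to which side chain it carries: exchanging one such chain for 1,2-dihydroxy-1-(trifluoromethyl)ethyl gives an at least 8.2-fold lower number from compound 2 to compound 3 (0.91 log units; beyond the scatter). Measured against hydrogen at this carbon, the same group gives an at least 28-fold lower number from compound 1 to compound 3 (1.45 log units; beyond the scatter), so both substituted compounds lie on the side of slower removal, and none of the compounds shown goes against this. Compound 3 stands at a limit of the assay and not at a number, so both new steps fix only a minimum size: the limit of < 14 mL.min-1.g-1 in this assay, at which 1 of the 3 values shown sits.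

The exchange removes the triple bond outside aromatic rings, shortens the chain and alters the hydrogen-bond donors and acceptors all at once, so the compounds shown cannot tell which of these changes goes with the fall. As far as these compounds go, a saturated chain in place of the one with the triple bond would separate these changes, while it remains open how an amine, a carboxylic acid or the opposite configuration at the defined stereocentre would read at this carbon.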